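Compound 4: 2-oxopyrrolidin-1-yl in place of the oxetane

A few compounds are considered here, and "the series" means these few. Any claim that something is new, unique, unknown or untested is made for them only; others in the source may bear on it.

Compound 1, `CC1(C#Cc2c(Cl)c3c(Cl)cc(C(N)=O)nc3n2[C@H]2CCCNC2)COC1`, gives 119 nM in a functional assay on KG-1 cells (Homo sapiens) for antiproliferative activity; a lower number here means that less compound is needed, a higher number that more compound is needed for the effect.
Compound 2, `NC(=O)c1cc(Cl)c2c(Cl)c(C#CCCO)n([C@H]3CCCNC3)c2n1`, gives 56 nM in this assay.
Compound 3, `CC1(CC#Cc2c(Cl)c3c(Cl)cc(C(N)=O)nc3n2[C@H]2CCCNC2)COC1`, gives 289 nM in this assay.

Compound 3 stands at the highest of the three numbers: the steps of a 2.4-fold higher number from compound 1 to compound 3 (0.39 log units; beyond the scatter) and a 5.2-fold higher number from compound 2 to compound 3 (0.71 log units; beyond the scatter) both lie beyond the scatter, so compound 3 needs more compound than either of the other two.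

Compound 4, `NC(=O)c1cc(Cl)c2c(Cl)c(C#CCN3CCCC3=O)n([C@H]3CCCNC3)c2n1`, differs from compound 3 in one place: 2-oxopyrrolidin-1-yl in place of 3-methyloxetan-3-yl on a saturated chain carbon bound to a triple-bonded carbon. The step that bears most directly on this change is a 5.2-fold higher number from compound 2 to compound 3 (0.71 log units; beyond the scatter), which altered the group at the same saturated chain carbon and moved the number modestly. The step of a 2.4-fold higher number from compound 1 to compound 3 (0.39 log units; beyond the scatter), a change on the triple-bonded carbon, was also modest. Together they show that changes in this chain shift the number only within a modest span, in either direction.

Compound 4 is therefore expected to land near the other two compounds rather than further up, with the step estimated as a 2.4-fold lower number from compound 3 to compound 4 (0.38 log units; beyond the scatter), a modest lowering that may still fall near the scatter. For compound 4 the estimate in this assay is 120 nM, in the range 40 nM to 400 nM.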

Compound 4, half-maximal effective concentration: 178 nM
Estimate against measurement, compound 4: 1.5-fold (0.17 log units) below, and the stated range covers the measured number.
By their numbers in this assay, from the lowest: compound 2; then compounds 1, 4 and 3 (each within the scatter of the next, the first and the last beyond it).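

In this assay, 2-oxopyrrolidin-1-yl in place of 3-methyloxetan-3-yl on a saturated chain carbon bound to a triple-bonded carbon gives a 1.6-fold lower number from compound 3 to compound 4 (0.21 log units; within the scatter) and so lies within the scatter: this assay does not separate these two ring groups at this carbon. The hydroxymethyl group of compound 2 does stand apart from both, with a 3.2-fold higher number from compound 2 to compound 4 (0.50 log units; beyond the scatter) joining a 5.2-fold higher number from compound 2 to compound 3 (0.71 log units; beyond the scatter) as steps beyond the scatter, so at this carbon the three groups shown fall into two levels, with hydroxymethyl alone on the lower side. The step of a 1.5-fold higher number from compound 1 to compound 4 (0.17 log units; within the scatter) also lies within the scatter, so compound 4 cannot be told from compound 1, even though the step of a 2.4-fold higher number from compound 1 to compound 3 (0.39 log units; beyond the scatter) lies beyond it.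

The compounds shown leave open how a dimethylamino group, a carboxylic acid or a longer chain ending in a hydroxyl group would compare at this carbon, and whether the hydroxyl group of compound 2 alone sets it apart from the two ring groups. No measurement offered here explains any of these differences.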